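From 2-chlorophenyl to 3-chlorophenyl on an amide-type nitrogen

The compounds below may be only part of what the source reports. "The series", "measured", "known", "first", "only" and "open" are said of these compounds alone.

In a functional assay on HT-29 cells (Homo sapiens) for antiproliferative activity, read by sulforhodamine B assay, with a stated time of 72 h (a higher number here means a weaker inhibitor, a lower number a stronger inhibitor), compound 1 `COc1ccc(NC(=O)Cn2nc(Cc3ccccc3)c3ccccc3c2=O)cc1` gives > 100000000 nM as a limit of the assay, not a number. Compound 2 `O=C(Cn1nc(Cc2ccccc2)c2ccccc2c1=O)Nc1ccc(F)cc1` gives 98000 nM and compound 3 `O=C(Cn1nc(Cc2ccccc2)c2ccccc2c1=O)Nc1ccccc1Cl` gives 42800 nM as the lowest number shown. The changes an at least 1000-fold lower number from compound 1 to compound 2 (3.00 log units; beyond the scatter) and an at least 2300-fold lower number from compound 1 to compound 3 (3.36 log units; beyond the scatter) are large but begin at that limit. Compound 4 `O=C(Cn1nc(Cc2ccccc2)c2ccccc2c1=O)Nc1cccc(Cl)c1` carries 3-chlorophenyl in place of 2-chlorophenyl on an amide-type nitrogen. The nearest guide is compound 3 with its modest change (a 2.3-fold lower number from compound 2 to compound 3 (0.36 log units; beyond the scatter)), so no step beyond the scatter is expected in this assay here. The estimated change is a 1.3-fold higher number from compound 3 to compound 4 (0.11 log units; within the scatter) with no firm direction. Compound 4 is expected at 55000 nM (estimated range 20000 nM to 130000 nM).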

Compound 4, half-maximal inhibitory concentration: 3680 nM
Compound 4: the middle estimate sits 15-fold (1.17 log units) above what was measured; the measured number lies below the stated range.
By their numbers in this assay, from the lowest: compound 4; then compound 3; then compound 2. At a limit, above all of these: compound 1.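

In this assay, 3-chlorophenyl in place of 2-chlorophenyl gives a 12-fold lower number from compound 3 to compound 4 (1.07 log units; beyond the scatter), so with the same atoms joined differently, the arrangement of this aryl group on the amide-type nitrogen matters more than the earlier modest step suggested. 3-Chlorophenyl in place of 4-fluorophenyl gives a 27-fold lower number from compound 2 to compound 4 (1.43 log units; beyond the scatter). 3-Chlorophenyl in place of 4-methoxyphenyl gives an at least 27000-fold lower number from compound 1 to compound 4 (4.43 log units; beyond the scatter), which cannot be read as an exact size, since compound 1 stands at a limit: the limit of > 100000000 nM in this assay, at which 1 of the 4 values shown sits.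

The compounds shown do not explain why the 3-chlorophenyl group gives the lowest number. From the compounds shown here alone, whether a bromine, a nitrile or an amine on this phenyl ring would lower it further remains open.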